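Removal of the basic butyl ether side chain: compound 4

A few compounds are considered here, and "the series" means these few. Any claim that something is new, unique, unknown or untested is made for them only; others in the source may bear on it.

Measured in an assay on CHO cells for inhibition of Vasopressin V2 receptor (Homo sapiens), read by radioligand binding; a lower number here means a stronger inhibitor, a higher number a weaker inhibitor:
compound 1 `CN(C)C1CCN(C(=O)CCCOc2cc(C(=O)N3CCCCc4sccc43)ccc2NC(=O)c2ccccc2-c2ccccc2)CC1`: 20 nM
compound 2 `CN1CCN(C(=O)CCCOc2cc(C(=O)N3CCCCc4sccc43)ccc2NC(=O)c2ccccc2-c2ccccc2)CC1`: 6 nM
compound 3 `CN1CCN(CCCCOc2cc(C(=O)N3CCCCc4sccc43)ccc2NC(=O)c2ccccc2-c2ccccc2)CC1`: 1 nM

Compound 3 stands lowest of the three numbers in this assay. The steps to it are a 20-fold lower number from compound 1 to compound 3 (1.30 log units; beyond the scatter) and a 6.0-fold lower number from compound 2 to compound 3 (0.78 log units; beyond the scatter), both beyond the scatter; the step of a 3.3-fold lower number from compound 1 to compound 2 (0.52 log units; beyond the scatter) is smaller. All three measured compounds keep the oxygen on the aromatic ring substituted with a four-carbon chain that ends in a basic amine, so the whole series differs only in the amine and in whether a carbonyl sits on that chain.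

Compound 4 `O=C(Nc1ccc(C(=O)N2CCCCc3sccc32)cc1O)c1ccccc1-c1ccccc1` differs from compound 3 by hydrogen in place of 4-(4-methylpiperazin-1-yl)butyl on an oxygen on an aromatic ring. Within the data shown here, no measured step bears directly on this change, as none of the measured pairs removes the side chain; the measured steps only show that reshaping the amine end moves the number by amounts between modest and large. Taking away the whole 4-(4-methylpiperazin-1-yl)butyl group is a larger change than any of them, so a clearly weaker number for compound 4 is expected, with wide uncertainty. For compound 4 the estimate in this assay is 300 nM, range 30 nM to 3000 nM, meaning an expected step of a 300-fold higher number from compound 3 to compound 4 (2.48 log units; beyond the scatter).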

Compound 4, half-maximal inhibitory concentration: < 10 nM
Compound 4: no number, only a limit; the forecaster's own chance of this, stated with the estimate: 10%; at least 30-fold (1.47 log units) between middle value and limit.
By their numbers in this assay, from the lowest: compound 3; then compound 2; then compound 1.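

In this assay compound 4 gives < 10 nM, which is a limit and not a number. The steps to compound 4 from compound 2 and compound 3 therefore cannot be read: the limit of < 10 nM in this assay, at which 1 of the 4 values shown sits. The compounds shown leave open how much removing the 4-(4-methylpiperazin-1-yl)butyl group from compound 3 changes the number in this assay, and in which direction.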